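A Halogen-to-Methyl Swap on the Aryl Amine Ring

The source may hold more compounds than are shown below. What is called first, only, known or untested is meant among the compounds shown, and "the series" means these compounds.

Three ureas have been measured in a functional assay on NCI-H226 cells (Homo sapiens) for inhibition, read by MTT assay, with a stated time of 48 h, tested at 10 uM; a higher number here means more inhibition at the concentration tested (going by the name of the read-out), a lower number less inhibition:
compound 1, `COc1cc(NC(=O)Nc2cc(Nc3ccc(C(C)(C)C)cc3)ncn2)cc(OC)c1`, gives 47.7%
compound 2, `CCc1ccc(Nc2cc(NC(=O)Nc3cc(OC)cc(OC)c3)ncn2)cc1`, gives 50.1%
compound 3, `COc1cc(NC(=O)Nc2cc(Nc3ccc(F)c(Cl)c3)ncn2)cc(OC)c1`, gives 36.7%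

Compound 3 stands lowest of the three: a number 11 percentage points lower from compound 1 to compound 3 (beyond the scatter) and a number 13.4 percentage points lower from compound 2 to compound 3 (beyond the scatter), whereas a number 2.4 percentage points higher from compound 1 to compound 2 (within the scatter). Compound 4, `COc1cc(NC(=O)Nc2cc(Nc3ccc(C)c(F)c3)ncn2)cc(OC)c1`, differs from compound 3 in one place: 3-fluoro-4-methylphenyl in place of 3-chloro-4-fluorophenyl on a nitrogen on an aromatic ring. The ring that enters carries a methyl together with a single fluorine, while the ring that leaves carried chlorine and fluorine. The two steps from alkyl-bearing rings to compound 3 were both modest losses, and compound 4 sits between those cases, so a modest gain is expected, a number 7.3 percentage points higher from compound 3 to compound 4 (within the scatter). Compound 4 is therefore estimated at 44%, with a range from 32% to 56%.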

Compound 4, a percentage reported as inhibition, at one concentration (the size of the read-out at that concentration, not a potency): 39.7%
Compound 4: the middle estimate sits 4.3 percentage points above what was measured, within the range that was stated.
By their numbers in this assay, from the lowest: compounds 3, 4, 1 and 2 (each within the scatter of the next, the first and the last beyond it).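

At this nitrogen, 3-fluoro-4-methylphenyl and 3-chloro-4-fluorophenyl cannot be told apart in this assay (a number 3 percentage points higher from compound 3 to compound 4 (within the scatter)). The ring of compound 4 does not match 4-ethylphenyl (a number 10.4 percentage points lower from compound 2 to compound 4 (beyond the scatter)), yet it stays within the scatter of 4-(tert-butyl)phenyl (a number 8 percentage points lower from compound 1 to compound 4 (within the scatter)), so these results do not separate the rings into one halogen-bearing and one alkyl-bearing group. No measurement shown explains these steps.

From the compounds shown here alone, how a ring bearing an amine or a carboxylic acid would behave at this nitrogen remains open.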